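The source may report more compounds than this note shows. Statements on the series, on what has been measured and on what is new or still open speak of the compounds shown alone.

Compound 3 `COc1cccc(C2=NN(C(=O)c3ccc(C)nc3)C(c3cn(C)c4ccc(OC)cc34)C2)c1` gives 590 nM in a functional assay on A549 cells (Homo sapiens) for inhibition, read by MTT assay, with a stated time of 48 h (on this read-out lower numbers stand for stronger inhibition of growth and higher numbers for weaker inhibition of growth), and so lies within the scatter of compound 1 `COc1ccc(C2=NN(C(=O)c3ccc(OC)nc3)C(c3cn(C)c4ccc(OC)cc34)C2)cc1`, which gives 450 nM there. Compound 2 `COc1ccc2c(c1)c(C1CC(c3cc(OC)c(OC)c(OC)c3)=NN1C(=O)c1ccc(OC)nc1)cn2C` reads > 10000 nM in this assay and this is a limit of the assay, not a number. For the measured compounds named here, the only measured step is an at least 22-fold higher number from compound 1 to compound 2 (1.34 log units; beyond the scatter) with 3,4,5-trimethoxyphenyl in place of 4-methoxyphenyl, and it rests on that limit. Compound 4 `COc1cccc(C2=NN(C(=O)c3ccc(OC)nc3)C(c3cn(C)c4ccc(OC)cc34)C2)c1` keeps the rest of compound 3 but has 6-methoxypyridin-3-yl instead of 6-methylpyridin-3-yl, that is, methoxy in place of methyl on an aromatic carbon describes the change. Going by the values given here, the large step lies elsewhere on the molecule, and no measured step touches this place, so no change beyond the scatter is expected in this assay here. Compound 1 carries the same 6-methoxypyridin-3-yl group and gives 450 nM in that read-out. The expected step is a 1.1-fold lower number from compound 3 to compound 4 (0.05 log units; within the scatter) and stays within the scatter. For compound 4 the estimate is 520 nM with an expected range from 200 nM to 1400 nM overall.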

Compound 4, concentration for 50% growth inhibition: 470 nM
Compound 4: the middle estimate sits 1.1-fold (0.04 log units) above what was measured; the range from low to high includes it.
By their numbers in this assay, from the lowest: compounds 1, 4 and 3 (each within the scatter of the next). At a limit, above all of these: compound 2.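

In this assay, methoxy in place of methyl on this aromatic carbon, next to the ring nitrogen, leaves the number within the scatter: a 1.3-fold lower number from compound 3 to compound 4 (0.10 log units; within the scatter). The other end of the molecule gains a second reading, as 3-methoxyphenyl and 4-methoxyphenyl cannot be told apart in this read-out: a 1.0-fold higher number from compound 1 to compound 4 (0.02 log units; within the scatter). With 3-methoxyphenyl as well, 3,4,5-trimethoxyphenyl stands apart, and the step of an at least 21-fold lower number from compound 2 to compound 4 (1.32 log units; beyond the scatter) rests, like the earlier one, on a limit of the assay for compound 2: the limit of > 10000 nM in this assay, at which 1 of the 4 values shown sits.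

The compounds shown leave open whether an amine or an ethoxy group at the pyridine position would also stay within the scatter. They also leave open whether a dimethoxyphenyl group on the other end would already raise the number.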